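A few compounds are considered here, and "the series" means these few. Any claim that something is new, unique, unknown or untested is made for them only; others in the source may bear on it.

Working notes on the series. Compound 2 `COc1ccccc1-c1cc(=O)c2cc(NC(C)=O)ccc2o1` gives 50000 nM in an ADME assay on THP-1 cells (Homo sapiens) for cytotoxicity, read by flow cytometry and propidium iodide staining, with a stated time of 72 h (a higher number here means a weaker inhibitor, a lower number a stronger inhibitor), the lowest of the three numbers measured, though every neighbour lies within the usual scatter: compound 3 `COc1ccccc1-c1cc(=O)c2cc(N)ccc2o1` gives 74000 nM in this assay, and compound 1 `CC(=O)Nc1ccc2oc(-c3ccccc3)cc(=O)c2c1` gives 97000 nM. The two measured steps are a 1.9-fold lower number from compound 1 to compound 2 (0.29 log units; within the scatter) and a 1.5-fold higher number from compound 2 to compound 3 (0.17 log units; within the scatter); neither rises above the scatter.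

The unmeasured compound 4 `COc1ccccc1-c1oc2ccc(NC(C)=O)cc2c(=O)c1OC` differs from compound 2 in one place: methoxy in place of hydrogen on an aromatic carbon. For the measured compounds named here, the only measured step of the same kind, methoxy in place of hydrogen on an aromatic carbon, is a 1.9-fold lower number from compound 1 to compound 2 (0.29 log units; within the scatter), made at a different site of the shared core; it stayed within the scatter. Going by the values given here, no measured step touches the site that changes here, so the bearing is indirect. Of the step of a 1.5-fold higher number from compound 2 to compound 3 (0.17 log units; within the scatter) nothing carries over, since the acetyl on the ring nitrogen is kept in compound 4.

Taken together, the measured steps give no ground to expect a shift beyond the scatter in this assay, in either direction; the expected step is no change at the digits printed from compound 2 to compound 4 (within the scatter). Compound 4 is therefore estimated at 50000 nM, with a range from 20000 nM to 120000 nM in this assay.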

Compound 4, half-maximal inhibitory concentration: 108000 nM
Beside the measured number, compound 4's estimate is 2.2-fold (0.33 log units) below it; the range from low to high includes it.
By their numbers in this assay, from the lowest: compounds 2, 3, 1 and 4 (each within the scatter of the next, the first and the last beyond it).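

In this assay, methoxy in place of hydrogen on the aromatic carbon of the six-membered aromatic ring with 1 oxygen, ortho to a 2-methoxyphenyl group, gives a 2.2-fold higher number from compound 2 to compound 4 (0.33 log units; beyond the scatter), a modest step and the only one shown at this position. The same replacement at a different site of the shared core stayed within the scatter, at a 1.9-fold lower number from compound 1 to compound 2 (0.29 log units; within the scatter), so in these compounds the size of the step is not the same at the two sites. Nothing shown accounts for this step, which stands as a measured number without an explanation.

The compounds shown leave open whether the step belongs to methoxy in particular or would also appear with hydroxy, ethoxy or chlorine on the same carbon. They also leave open whether it carries over to a parent with the free amine of compound 3 or with the unsubstituted phenyl of compound 1, since a single pair defines this position.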